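From cyclopropylamino to oxetan-3-yl on a sulfonyl sulfur

The compounds below may be only part of what the source reports. "The series", "measured", "known", "first", "only" and "open" are said of these compounds alone.

In an ADME assay on microsomes from liver (Mus musculus) for metabolic stability, read by LC-MS, with a stated time of 40 min, tested at 0.5 uM (on this read-out higher numbers stand for fast clearance and lower numbers for slow clearance), compound 1 (`CC(C)(CO)S(=O)(=O)c1cccc(NC(=O)c2cccnc2N2CCC3(CC2)CC3)c1`) gives > 399 mL.min-1.g-1 which is a limit and not a number. Compound 2 (`CC(C)(C)NS(=O)(=O)c1cccc(NC(=O)c2cccnc2N2CCC3(CC2)CC3)c1`) gives > 399 mL.min-1.g-1 which is also a limit. Compound 3 (`O=C(Nc1cccc(S(=O)(=O)NC2CC2)c1)c1cccnc1N1CCC2(CC1)CC2`) gives > 399 mL.min-1.g-1 which is likewise a limit, so it has no exact value to start from.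

Compound 4 (`O=C(Nc1cccc(S(=O)(=O)C2COC2)c1)c1cccnc1N1CCC2(CC1)CC2`) differs from compound 3 as follows: oxetan-3-yl in place of cyclopropylamino on a sulfonyl sulfur with cyclopropylsulfamoyl becoming (oxetan-3-yl)sulfonyl.

The measured record amounts to the limit of > 399 mL.min-1.g-1 in this assay, at which 3 of the 3 values shown sit, and nothing finer. Two exchanges on the same sulfur bear on this change, namely a step that the two limits leave unreadable from compound 1 to compound 3 and a step that the two limits leave unreadable from compound 2 to compound 3 and neither has a size that can be read. The outcome expected in this assay is no step beyond the scatter and no favoured direction, estimated as a step that the limit leaves unreadable from compound 3 to compound 4 in size. The estimate for compound 4 is 400 mL.min-1.g-1 with an expected range from 200 mL.min-1.g-1 to 800 mL.min-1.g-1 and another limit is the likeliest report.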

Compound 4, intrinsic clearance in microsomes: 385 mL.min-1.g-1
For compound 4 the middle estimate is 1.0-fold (0.02 log units) above the measured one, within the range that was stated.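

In this assay, within the data shown here, compound 4 gives 385 mL.min-1.g-1 as an exact number, so oxetan-3-yl on a sulfonyl sulfur provides the only value in this set that is not a limit. The other three compounds remain limits: the limit of > 399 mL.min-1.g-1 in this assay, at which 3 of the 4 values shown sit. Against these limits only floors can be read, namely an at least 1.0-fold lower number from compound 3 to compound 4 (0.01 log units; that floor lies within the scatter) and an at least 1.0-fold lower number from compound 2 to compound 4 (0.01 log units; that floor lies within the scatter) and also an at least 1.0-fold lower number from compound 1 to compound 4 (0.01 log units; that floor lies within the scatter) (so the true size of each step stays unknown).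

The steps among compound 1, compound 2 and compound 3 cannot be read. Going by these compounds, whether another group on the sulfonyl sulfur, such as a plain methyl or a morpholine ring joined through its nitrogen, would bring the clearance clearly lower than in compound 4 stays open.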